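Swapping the fluorophenyl ring for a pyrimidine on the oxazole

This account rests on a few compounds, and the source may have more. Where it says the series, first, only, none or still open, it means among the compounds named here.

Measured compounds:
- compound 1, `O=C(CCCCCCc1ccccc1)c1ncc(-c2ccccc2C(=O)C(F)(F)F)o1`: 5000 nM
- compound 2, `O=C(CCCCCCc1ccccc1)c1ncc(-c2ccc(F)cc2)o1`: 62 nM

Both compounds were tested in an assay (Rattus norvegicus) for inhibition of Fatty-acid amide hydrolase 1 (Homo sapiens); a lower number here means a stronger inhibitor, a higher number a weaker inhibitor. Compound 1, which carries a trifluoroacetyl-substituted phenyl ring on the shared core, gives 5000 nM. Compound 2, with a 4-fluorophenyl ring in that place, gives 62 nM, the lower of the two numbers and therefore the stronger inhibitor; the gap to compound 1 lies well beyond the usual scatter of this kind of measurement. Since the two compounds differ in more than one feature, that gap cannot be assigned to a single change.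

The next compound, compound 3, `O=C(CCCCCCc1ccccc1)c1ncc(-c2ncccn2)o1`, is not yet measured. It differs from compound 2 in one place: pyrimidin-2-yl in place of 4-fluorophenyl on an aromatic carbon. The ring that enters brings two hydrogen-bond acceptors where the 4-fluorophenyl ring brought none. Going by the values given here, with no measured pair that isolates this kind of exchange, the direction of the step is judged from the structural change alone. A modest gain in potency is expected, with the step of a 4.1-fold lower number from compound 2 to compound 3 (0.62 log units; beyond the scatter) estimated to fall somewhat beyond the scatter. Compound 3 is estimated to give 15 nM, within a range from 4 nM to 60 nM.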

Compound 3, inhibition constant: 5.3 nM
The estimate for compound 3 lay 2.8-fold (0.45 log units) above the measured number; the range from low to high includes it.
By their numbers in this assay, from the lowest: compound 3; then compound 2; then compound 1.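

Going by these compounds alone, exchanging 4-fluorophenyl for pyrimidin-2-yl gives a 12-fold lower number from compound 2 to compound 3 (1.07 log units; beyond the scatter) in this assay, and this is the first comparison here in which only one place changes. It shows that the group on this aromatic carbon, next to the ring oxygen, can by itself move the number by a large margin, even though both groups are six-membered aromatic rings and the rest of the molecule stays the same. The exchange also replaces a ring of carbon only, with no hydrogen-bond acceptors, by a ring with two nitrogens and two acceptors, but no measurement here tells why the number falls.

Because the fluorine leaves as the ring nitrogens enter, this one step cannot separate the loss of the fluorine from the gain of the nitrogens, and a plain phenyl ring or a pyridin-2-yl ring, with a single ring nitrogen, would help to pull those two changes apart. Going by these compounds, it also remains open how much more this position tolerates, for instance a pyrimidin-2-yl ring that carries an added amine or carboxylic acid.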